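This account rests on a few compounds, and the source may have more. Where it says the series, first, only, none or still open, it means among the compounds named here.

Compound 1 `CC(C)=CCc1cc(C(=O)Nc2cc3ccc(OCCCN4CCCCC4)c(C)c3oc2=O)ccc1O`: > 50000 nM (a limit)
Compound 2 `CCCN(CCC)CCCOc1ccc2cc(NC(=O)c3ccc(O)c(CC=C(C)C)c3)c(=O)oc2c1C`: > 50000 nM (a limit)
Compound 3 `CC(C)=CCc1cc(C(=O)Nc2cc3ccc(OCCCNC4CCCCC4)c(C)c3oc2=O)ccc1O`: 660 nM

All three were tested in a functional assay on SK-BR-3 cells (Homo sapiens) for antiproliferative activity; on this read-out higher numbers stand for weaker inhibition and lower numbers for stronger inhibition. For the measured compounds named here, compound 3 has the only actual number, and the other two values are limits, as the limit of > 50000 nM in this assay, at which 2 of the 3 values shown sit, shows.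

The next compound is compound 4 `CC(C)=CCc1cc(C(=O)Nc2cc3ccc(OCCCNCc4ccccc4)c(C)c3oc2=O)ccc1O`, which has benzyl in place of cyclohexyl on an amine nitrogen.

The measured steps bearing on this change are at the same amine nitrogen. These are an at least 75-fold lower number from compound 1 to compound 3 (1.87 log units; beyond the scatter) and an at least 75-fold lower number from compound 2 to compound 3 (1.87 log units; beyond the scatter), both large. The step that the two limits leave unreadable from compound 1 to compound 2 adds no size. None of these steps compares benzyl with cyclohexyl, so they set no direct size for the new change. Compound 4 keeps the benzylamino counterpart of cyclohexylamino rather than piperidin-1-yl or dipropylamino, so a step as large as an at least 75-fold lower number from compound 2 to compound 3 (1.87 log units; beyond the scatter) is not expected. A modest move towards a higher number is expected from the anchor of compound 3 at 660 nM.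

The expected change is a 2.3-fold higher number from compound 3 to compound 4 (0.36 log units; beyond the scatter).

The estimate for compound 4 is 1500 nM, with an expected range from 300 nM to 10000 nM.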

Compound 4, half-maximal inhibitory concentration: 470 nM
Compound 4: middle estimate off by 3.2-fold (0.50 log units), on the high side, and the stated range covers the measured number.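

In this assay, benzyl and cyclohexyl on this amine nitrogen give no readable difference, with a 1.4-fold lower number from compound 3 to compound 4 (0.15 log units; within the scatter), so an aromatic ring here serves as well as a saturated one. The benzylamino group also keeps the wide separation from the other two amines, with an at least 100-fold lower number from compound 2 to compound 4 (2.02 log units; beyond the scatter) and an at least 100-fold lower number from compound 1 to compound 4 (2.02 log units; beyond the scatter), so this separation is no longer tied to cyclohexylamino alone. Compound 1 and compound 2 each give a limit and not a number, so these two steps are bounds: the limit of > 50000 nM in this assay, at which 2 of the 4 values shown sit.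

From the compounds shown here alone, it remains open whether a 2-phenylethylamino group or an unsubstituted primary amine at this position would stay in the range of compound 3 and compound 4. A longer chain between the ring oxygen and the amine is also untested among the compounds shown.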